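Swapping Fluoro for Bromo on a Shared Core

The source may hold more compounds than are shown below. What is called first, only, known or untested is meant among the compounds shown, and "the series" means these compounds.

Compound 1, `CCN(C(=O)c1c(O)c2c(C)cccc2n(C)c1=O)c1ccccc1`: 65%
Compound 2, `CCN(C(=O)c1c(O)c2c(F)cccc2n(C)c1=O)c1ccccc1`: 60%
Compound 3, `CC(C)N(C(=O)c1c(O)c2c(Cl)cccc2n(C)c1=O)c1ccccc1`: 54%

All three were tested in a functional assay on the whole organism for inhibition, with Mus musculus as the target, at a dose of 1 mg/kg by the oral route; on this read-out lower numbers stand for less inhibition and higher numbers for more inhibition at the one dose given (going by the name of the read-out). Compound 2 stands second highest of the three numbers; its nearest neighbour compound 1 gives 65%, and compound 3 gives 54%, both within the scatter of compound 2.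

Compound 4, `CCN(C(=O)c1c(O)c2c(Br)cccc2n(C)c1=O)c1ccccc1`, differs from compound 2 by bromo in place of fluoro on an aromatic carbon. Among the measured compounds shown here, only one measured step concerns this aromatic carbon: a number 5 percentage points lower from compound 1 to compound 2 (within the scatter). Compound 3 carries chloro there but also a different group elsewhere, so its number is not a clean comparison. For the measured compounds named here, with one small step as the only guide, no change beyond the scatter is expected in this assay; the expected step is no change at the digits printed from compound 2 to compound 4 (within the scatter). Compound 4 is therefore estimated at 60%, within 48% to 72%.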

Compound 4, a percentage reported as inhibition, in the whole organism at one dose (the size of the read-out at that dose, not a potency): 95%
The estimate for compound 4 lay 35 percentage points below the measured number; the measured number lies above the stated range.
By their numbers in this assay, from the lowest: compounds 3, 2 and 1 (each within the scatter of the next, the first and the last beyond it); then compound 4.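

In this assay this aromatic carbon turns out to be sensitive to its group: bromo in place of fluoro gives a number 35 percentage points higher from compound 2 to compound 4 (beyond the scatter) as the step, and bromo in place of methyl gives a number 30 percentage points higher from compound 1 to compound 4 (beyond the scatter) as the step. Fluoro and methyl had stayed within the scatter of each other, so only bromo separates from them here. No available evidence explains this result.

Chloro appears only alongside a different group elsewhere, so its own effect on this carbon stays unseparated. The compounds shown also leave open how iodo, methoxy or an amine would behave on this carbon, and whether bromo keeps its advantage with other groups elsewhere on the shared core.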